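The source may hold more compounds than are shown below. What is called first, only, known or untested is meant among the compounds shown, and "the series" means these compounds.

Measured so far:
- Compound 1, `Cc1nc(-c2ccc(F)cc2)c(C(=O)N2CCN(c3ccc(C(=O)C(C)C)cc3)CC2)o1`: "not active" (no number reported) in a functional assay on HL-60 cells (Homo sapiens) for inhibition, read by MTT assay, with a stated time of 72 h; on this read-out higher numbers stand for weaker inhibition and lower numbers for stronger inhibition
- Compound 2, `Cc1nc(-c2ccccc2F)c(C(=O)N2CCN(c3cccc(Cl)c3)CC2)o1`: 39.4 nM
- Compound 3, `Cc1nc(-c2ccccc2)c(C(=O)N2CCN(c3cccc(C(N)=O)c3)CC2)o1`: 71 nM

Three compounds share the same core and differ in the aryl group on the amine nitrogen of the six-membered ring and in the aryl group on the core. Compound 1 gave no number in this assay and was reported as not active. Of the two numbers that exist, compound 3 carries the higher one, but its gap to compound 2 lies within the usual scatter of this assay, so the two cannot be ranked against each other.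

Compound 4, `Cc1nc(-c2ccccc2)c(C(=O)N2CCN(c3c(C)cccc3C)CC2)o1`, has not yet been measured. It differs from compound 3 in one place: 2,6-dimethylphenyl in place of 3-carbamoylphenyl on an amine nitrogen in a ring. The group that leaves brings one hydrogen-bond donor and one acceptor; the group that enters brings neither.

Within the data shown here, with no measured step of the same kind to lean on, the expectation for this assay is a step of no clear direction, most likely staying within the scatter around compound 3, though a wider spread is possible. The estimated step is a 1.3-fold higher number from compound 3 to compound 4 (0.10 log units; within the scatter). Compound 4 is therefore expected to give about 90 nM, with a likely range from 30 nM to 300 nM.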

Compound 4, half-maximal inhibitory concentration: 146 nM
Beside the measured number, compound 4's estimate is 1.6-fold (0.21 log units) below it; low and high end bracket the measured number.
By their numbers in this assay, from the lowest: compounds 2 and 3 (each within the scatter of the next); then compound 4.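

In this assay, among these compounds, putting 2,6-dimethylphenyl in place of 3-carbamoylphenyl on the amine nitrogen in the ring gives a 2.1-fold higher number from compound 3 to compound 4 (0.31 log units; beyond the scatter), the only step here that changes one place alone, and it lies just beyond the usual scatter. The position therefore accepts a group with 0 hydrogen-bond donors and 0 hydrogen-bond acceptors at a modest cost: the carbamoyl group is not needed for compound 4 to give a measured number, although the number is higher than that of compound 3. Nothing available explains the rise.

This one change removes the carbamoyl group and adds the methyl groups together, so the compounds shown cannot tell how much of the step belongs to the loss of one and how much to the arrival of the other. Also open, as far as these compounds go, is how the number would respond to an unsubstituted phenyl at this position, to a phenyl carrying a single methyl group, or to a phenyl carrying a carboxylic acid or an aminomethyl group in place of the carbamoyl group.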